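Swapping the thiazole for a pyrazole on the shared core

A few compounds are considered here, and "the series" means these few. Any claim that something is new, unique, unknown or untested is made for them only; others in the source may bear on it.

Two compounds share a core and differ only in the five-membered ring attached to it. Compound 1 `c1cc(-c2ccn[nH]2)c2c(c1)C(c1ncc[nH]1)CC2` carries a 1H-pyrazol-5-yl group and in a functional assay on CHO cells for agonist activity at Alpha-1D adrenergic receptor (Homo sapiens), read by FLIPR and calcium flux (a higher number here means that more compound is needed for the effect, a lower number that less compound is needed), gives 336 nM. Within the data shown here, compound 2 `c1cc(-c2nccs2)c2c(c1)C(c1ncc[nH]1)CC2` carries a 1,3-thiazol-2-yl group instead and in this assay gives 3190 nM, the higher of the two numbers measured so far; the single measured step, a 9.5-fold higher number from compound 1 to compound 2 (0.98 log units; beyond the scatter), separates them. Compound 3 `c1cc(-c2cn[nH]c2)c2c(c1)C(c1ncc[nH]1)CC2` has not yet been measured; relative to compound 2 it has 1H-pyrazol-4-yl in place of 1,3-thiazol-2-yl on an aromatic carbon. Among the measured compounds shown here, the one step bearing on this change, a 9.5-fold higher number from compound 1 to compound 2 (0.98 log units; beyond the scatter), read in reverse shows that replacing the thiazole with a pyrazole lowered the number well beyond the scatter, though the pyrazole is attached through a different atom here. Compound 3 is therefore expected to show a 4.0-fold lower number from compound 2 to compound 3 (0.60 log units; beyond the scatter), landing nearer to compound 1. Compound 3 is estimated at 800 nM, within 200 nM to 3500 nM.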

Compound 3, half-maximal effective concentration: 319 nM
The estimate for compound 3 lay 2.5-fold (0.40 log units) above the measured number, and the stated range covers the measured number.
By their numbers in this assay, from the lowest: compounds 3 and 1 (each within the scatter of the next); then compound 2.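

In this assay, putting 1H-pyrazol-4-yl in place of 1,3-thiazol-2-yl on the aromatic carbon gives a clear change (a 10-fold lower number from compound 2 to compound 3 (1.00 log units; beyond the scatter)), so a second pyrazole attachment now stands apart from the thiazole. Moving the attachment of the pyrazole from the 5-yl to the 4-yl form leaves the number within the scatter (a 1.1-fold lower number from compound 1 to compound 3 (0.02 log units; within the scatter)), so in this assay the two pyrazoles cannot be told apart, and both have lower numbers than the thiazole. The pyrazoles carry 1 hydrogen-bond donor and the thiazole 0, but nothing measured here says what lies behind the difference in their numbers.

Still open, going by these compounds, is how a pyrazole with a methyl group on its ring nitrogen would compare with these two pyrazoles. Equally open, on these data alone, is how a six-membered pyridine ring would fare at this position.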